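A few compounds are considered here, and "the series" means these few. Any claim that something is new, unique, unknown or untested is made for them only; others in the source may bear on it.

Compound 1 `COC(=O)C1=C(C)NC(C)=C(C(=O)OC)C1c1c(-c2c(Cl)csc2Cl)nc2sc(C)cn12`: 310 nM
Compound 2 `COC(=O)C1=C(C)NC(C)=C(C(=O)OC)C1c1c(-c2ccccn2)nc2sccn12`: 540 nM

Both values come from a functional assay on cardiac atrium (Cavia porcellus); on this read-out higher numbers stand for an effect only at larger amounts of compound and lower numbers for an effect already at smaller amounts. Compound 2, at 540 nM, lies within the usual scatter of compound 1, at 310 nM. Compound 3 `COC(=O)C1=C(C)NC(C)=C(C(=O)OC)C1c1c(-c2c(Cl)csc2Cl)nc2sccn12` gives up the pyridin-2-yl of compound 2, on an aromatic carbon, for a group with a five-membered aromatic ring: a group of 7 heavy atoms (4 carbon, 1 sulfur, 2 chlorine; one five-membered aromatic ring with 1 hetero atom) in place of a group of 6 heavy atoms (5 carbon, 1 nitrogen; one six-membered aromatic ring with 1 hetero atom), on an aromatic carbon. For the measured compounds named here, no measured step shows what this exchange does in this assay, so no step beyond the scatter is expected. The expected 1.4-fold lower number from compound 2 to compound 3 (0.15 log units; within the scatter) is small, and its direction is uncertain. For compound 3 the estimated value is 380 nM, with an expected range of 130 nM to 1100 nM.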

Compound 3, half-maximal effective concentration: 46 nM
Beside the measured number, compound 3's estimate is 8.3-fold (0.92 log units) above it; measured number below the stated range.
By their numbers in this assay, from the lowest: compound 3; then compounds 1 and 2 (each within the scatter of the next).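

In this assay, the group on this aromatic carbon next to the ring nitrogen proves to matter: the five-membered aromatic ring carrying sulfur and two chlorine in place of pyridin-2-yl gives a large step (a 12-fold lower number from compound 2 to compound 3 (1.07 log units; beyond the scatter)). The second place matters too, as hydrogen in place of methyl on an aromatic carbon gives a modest step (a 6.7-fold lower number from compound 1 to compound 3 (0.83 log units; beyond the scatter)). No measurement at hand explains either step. The compounds shown leave open whether the ring or its chlorine atoms carry the first step, which an unsubstituted thienyl group could separate. They also leave open how an ethyl group or an amine would fare in place of that hydrogen.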